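Ester Variation on a Furan Cyanoacrylate Series

The source may hold more compounds than are shown below. What is called first, only, known or untested is meant among the compounds shown, and "the series" means these compounds.

Compound 3 `CC(C)CCOC(=O)/C(C#N)=C/c1ccoc1` gives 82.2% in a functional assay on the whole organism (strain CD1) for inhibition, with Mus musculus as the target, with stated times of 15 min and 20 min, at a dose of 10 mg/kg by the subcutaneous route (on this read-out lower numbers stand for less inhibition and higher numbers for more inhibition at the one dose given (going by the name of the read-out)), the highest of the three numbers measured, though compound 2 `CC(C)(C)OC(=O)/C(C#N)=C/c1ccoc1` with 81.8% lies within the scatter of it; only compound 1 `N#C/C(=C\c1ccoc1)C(=O)O` with 30.7% stands apart, and the steps of a number 51.1 percentage points higher from compound 1 to compound 2 (beyond the scatter) and a number 51.5 percentage points higher from compound 1 to compound 3 (beyond the scatter) were both large. Compound 4 `N#C/C(=C\c1ccoc1)C(=O)OC1CCCCC1` differs from compound 3 by cyclohexyl in place of isopentyl on an oxygen next to a carbonyl group. The step that bears on this is a number 0.4 percentage points higher from compound 2 to compound 3 (within the scatter), where one alkyl group replaced another on that oxygen without effect beyond the scatter. Compound 4 is therefore expected to show no step beyond the scatter, namely a number 2.2 percentage points lower from compound 3 to compound 4 (within the scatter). Compound 4 is estimated at 80%, in a range from 65% to 92%.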

Compound 4, a percentage reported as inhibition, in the whole organism at one dose (the size of the read-out at that dose, not a potency): 91.2%
Beside the measured number, compound 4's estimate is 11.2 percentage points below it; the measured number falls inside the stated range.
By their numbers in this assay, from the lowest: compound 1; then compounds 2, 3 and 4 (each within the scatter of the next).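

In this assay, a ring on an oxygen next to a carbonyl group fits the same picture as the two open-chain groups: cyclohexyl stays within the scatter of both, with a number 9 percentage points higher from compound 3 to compound 4 (within the scatter) and a number 9.4 percentage points higher from compound 2 to compound 4 (within the scatter). Set against hydrogen at this place, cyclohexyl also gives a large change, a number 60.5 percentage points higher from compound 1 to compound 4 (beyond the scatter), making it the third carbon group to stand apart from hydrogen. Nothing measured here accounts for that gap. The compounds shown leave open whether a benzyl group or a longer chain on that oxygen would keep the number at this level, and whether an amide in place of the ester would do so.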